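Notes on the step from compound 3 to compound 4

The source may hold more compounds than are shown below. What is called first, only, known or untested is meant among the compounds shown, and "the series" means these compounds.

In a functional assay on DU-145 cells (Homo sapiens) for inhibition, read by trypan blue exclusion, with a stated time of 96 h (a lower number here means a stronger inhibitor of growth, a higher number a weaker inhibitor of growth), compound 3 `Cc1ccc(/C=C(\C(=O)c2ccc(Br)cc2)S(=O)(=O)Cc2ccc(F)cc2)s1` gives 1000 nM, the lowest of three values, against compound 1 `Cc1ccc(S(=O)(=O)/C(=C/c2ccc(C)s2)C(=O)c2ccc(Br)cc2)cc1` at 25000 nM and compound 2 `Cc1ccc(/C=C(\C(=O)c2ccc(Cl)cc2)S(=O)(=O)Cc2ccc(F)cc2)s1` at 50000 nM. Compound 4 `O=C(/C(=C\c1ccc(O)cc1)S(=O)(=O)Cc1ccc(F)cc1)c1ccc(Br)cc1` has 4-hydroxyphenyl in place of 5-methylthiophen-2-yl on a double-bonded chain carbon bound to a double-bonded chain carbon. Among the compounds with values here, no measured step touches this place. The large 25-fold lower number from compound 1 to compound 3 (1.40 log units; beyond the scatter) came with a change on a sulfonyl sulfur, and the large 50-fold lower number from compound 2 to compound 3 (1.70 log units; beyond the scatter) with bromo in place of chloro. Both leave the direction here open, but compound 3 at 1000 nM is the lowest so far, so a higher number is expected in this assay. The expected step is a 3.0-fold higher number from compound 3 to compound 4 (0.48 log units; beyond the scatter), with wide uncertainty. For compound 4 the estimated value is 3000 nM, with an expected range of 300 nM to 30000 nM.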

Compound 4, concentration for 50% growth inhibition: 10000 nM
Estimate against measurement, compound 4: 3.3-fold (0.52 log units) below, within the range that was stated.
By their numbers in this assay, from the lowest: compound 3; then compound 4; then compounds 1 and 2 (each within the scatter of the next).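

This place, on a double-bonded chain carbon bound to a double-bonded chain carbon, responds to substitution: 4-hydroxyphenyl in place of 5-methylthiophen-2-yl gives a 10-fold higher number from compound 3 to compound 4 (1.00 log units; beyond the scatter) in this assay. The position therefore joins the sulfonyl sulfur substituent and the halogen as a place where a single change moves the number beyond the scatter. Nothing on hand gives a reason for this step.

From the compounds shown here alone, the ring and the hydroxyl change together, so which of them carries the step stays open. Also open, going by these compounds, is how phenyl, 4-methoxyphenyl or 4-aminophenyl would compare at this place.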